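From Chloro to Trifluoromethoxy in a Growth Inhibition Series

The source may report more compounds than this note shows. Statements on the series, on what has been measured and on what is new or still open speak of the compounds shown alone.

Three compounds have so far been examined in a functional assay on PC-3 cells (Homo sapiens) for inhibition, read by MTT assay, with a stated time of 24 h, tested at 1 ug/mL (on this read-out higher numbers stand for more inhibition of growth at the one concentration tested and lower numbers for less inhibition of growth), and only one of them has produced a number. Compound 1 (`O=C(CCCCC1CCSS1)Nc1ccc(OC(F)(F)F)cc1`) gives 10.8%. Compound 2 (`O=C(CCCCC(S)CCS)Nc1ccc(Cl)cc1`) has no such figure: its entry reads "not determined" (no result reported), so it cannot be placed on the scale at all. Compound 3 (`O=C(CCCCC(S)CCS)Nc1cccc(C(F)(F)F)c1`) is in the same position, with an entry of "not determined" (no result reported). Within the data shown here, no pair of measured compounds therefore shows what a single structural change does in this assay.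

The next compound to be tested is compound 4 (`O=C(CCCCC(S)CCS)Nc1ccc(OC(F)(F)F)cc1`). The step trifluoromethoxy in place of chloro on an aromatic carbon places trifluoromethoxy in place of chloro on an aromatic carbon, para to a large group, and leaves the rest of the structure untouched. Among the measured compounds shown here, with no measured step to serve as a guide, no direction can be given, and no step beyond the usual scatter is expected from this swap in this assay. For the measured compounds named here, the only available anchor is compound 1 at 10.8%, and it is a loose one, since it is not the compound being changed here. For compound 4 the estimated inhibition is 14%, with an expected range from 2% to 35%.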

Compound 4, percent growth inhibition at one concentration: 12.6%
The estimate for compound 4 lay 1.4 percentage points above the measured number; low and high end bracket the measured number.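

Among these compounds, this is the first step that can be read. Putting the open chain of compound 4 in place of the five-membered non-aromatic ring of compound 1, on a saturated chain carbon four bonds along the chain from a carbonyl carbon, gives this result in this assay: a number 1.8 percentage points higher from compound 1 to compound 4 (within the scatter). With trifluoromethoxy the same in both compounds, the ring and the open chain therefore cannot be told apart at this position at the one concentration tested, although a single low-level comparison says little about other concentrations. No measurement is available that could explain this result.

On these data alone, the step from chloro to trifluoromethoxy cannot be read, and neither can any other step involving compound 2 or compound 3, since neither compound has a number, so the effect of changing the group on the aromatic ring remains unknown. Also open, as far as these compounds go, is whether an amine or a carboxylic acid in that place, or a longer chain in place of the saturated chain, would move the number beyond the scatter.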